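A Sulfamoyl Replacement on an Unreadable Baseline

The compounds below may be only part of what the source reports. "The series", "measured", "known", "first", "only" and "open" are said of these compounds alone.

Within the data shown here, compound 1 `CCOC(=O)c1nn(C)c2c1CN(C(=O)Nc1ccc(Cl)cc1)CC2` is one of three compounds measured in an assay on cells for inhibition of Pendrin (Mus musculus), read by fluorescence, with a stated time of 10 min; on this read-out lower numbers stand for stronger inhibition and higher numbers for weaker inhibition. In this assay compound 1 gives only a limit, > 10000 nM. Compound 2 `Cn1nc(COc2cc(F)cc(F)c2)c2c1CCN(C(=S)Nc1ccc(Cl)cc1)C2` likewise gives only a limit in this assay, > 10000 nM. Compound 3 `CN(C)c1ccc(NC(=S)N2CCc3c(c(COc4cc(F)cc(F)c4)nn3C)C2)cc1` also reaches no number in this assay and sits at the limit > 10000 nM. Among the measured compounds shown here, the one single-point step among them, a step that the two limits leave unreadable from compound 2 to compound 3, cannot be read, because the limit of > 10000 nM in this assay, at which 3 of the 3 values shown sit, places every value shown at the same limit. Compound 2 therefore stands nowhere on a scale; it is known only to be weak in this assay.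

Compound 4 `CCN(CC)S(=O)(=O)N1CCc2c(c(COc3cc(F)cc(F)c3)nn2C)C1` differs from compound 2 by a group of 8 heavy atoms (4 carbon, 1 nitrogen, 2 oxygen, 1 sulfur; no ring) in place of a group of 10 heavy atoms (7 carbon, 1 nitrogen, 1 sulfur, 1 chlorine; one six-membered aromatic ring of carbon only), on an amine nitrogen in a ring. For the measured compounds named here, no measured step bears on this change, and the one step available is itself unreadable, so no direction or size can be anticipated beyond the scatter. Compound 4 is expected to give 15000 nM, within 4000 nM and 60000 nM, most probably as a limit again. The estimated step is a step that the limit leaves unreadable from compound 2 to compound 4.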

Compound 4, half-maximal inhibitory concentration: > 10000 nM
Compound 4 gave a limit, no number (the forecaster's own chance of this, stated with the estimate: 85%); the middle value does not contradict the limit.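

No new step can be read: the change from compound 2 to compound 4 stays unreadable, because both compounds sit at the same limit: the limit of > 10000 nM in this assay, at which 4 of the 4 values shown sit.

The compounds shown leave open which change, if any, would give a readable number in this assay, and how the diethylsulfamoyl group compares with the group it replaces.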